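A few compounds are considered here, and "the series" means these few. Any claim that something is new, unique, unknown or untested is made for them only; others in the source may bear on it.

Working notes on the series.

Among the compounds with values here, compound 1 `Cc1ccc(-n2nncc2CN2C(=O)C3(C(C#N)=C(N)Oc4c3c3nc5ccccc5nc3c3ccccc43)c3ccccc32)cc1Cl` is the first member. In an ADME assay on L02 cells (Homo sapiens) for antiproliferative activity, read by MTT assay, with a stated time of 48 h (on this read-out higher numbers stand for weaker inhibition and lower numbers for stronger inhibition), compound 1 gives only a limit of the assay, > 50000 nM, and no number. Compound 2 `Cc1ccc(Cl)cc1-n1nncc1CN1C(=O)C2(C(C#N)=C(N)Oc3c2c2nc4ccccc4nc2c2ccccc32)c2ccccc21` differs from it in a single place, (5-chloro-2-methylphenyl in place of 3-chloro-4-methylphenyl on an aromatic nitrogen). In this assay compound 2 likewise gives only a limit, > 50000 nM. The step that the two limits leave unreadable from compound 1 to compound 2 therefore cannot be read; both ends sit at the same limit.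

Compound 3 `Cc1ccc(-n2nncc2CN2C(=O)C3(C(C#N)=C(N)Oc4c(N)cc5nc6ccccc6nc5c43)c3ccccc32)cc1Cl` carries a different core; the difference between the core of compound 1 and the core of compound 3 is not broken down here. In this assay compound 3 gives only a limit, > 50000 nM, and no number. Thus every value in hand sits at the same place, (the limit of > 50000 nM in this assay, at which 3 of the 3 values shown sit).

Compound 4 `Cc1ccc(Cl)cc1-n1nncc1CN1C(=O)C2(C(C#N)=C(N)Oc3c(N)cc4nc5ccccc5nc4c32)c2ccccc21` has not yet been measured. It stands to compound 3 as compound 2 stands to compound 1: 5-chloro-2-methylphenyl in place of 3-chloro-4-methylphenyl on an aromatic nitrogen. The surroundings of the change are described in identical words for both pairs, so the two changes are the same change on two cores.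

The expected step that the limit leaves unreadable from compound 3 to compound 4 is, on that footing, an unreadable one, resting on compound 1 at > 50000 nM, compound 2 at > 50000 nM and compound 3 at > 50000 nM, all of which sit at the limit (the limit of > 50000 nM in this assay, at which 3 of the 3 values shown sit). The estimate for compound 4 in this assay is 80000 nM, within 30000 nM to 300000 nM, with the most likely outcome a limit rather than a number.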

Compound 4, half-maximal inhibitory concentration: > 50000 nM
Compound 4: no number, only a limit; the forecaster's own chance of this, stated with the estimate: 85%; the middle value lies beyond the limit too.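

The step from compound 3 to compound 4 cannot be read, as both compounds sit at a limit and not at a number, so this result adds no readable step: the limit of > 50000 nM in this assay, at which 4 of the 4 values shown sit.

The compounds shown leave open whether 3-chloro-4-methylphenyl and 5-chloro-2-methylphenyl, or the core of compound 1 and the core of compound 3, differ at all in this assay, as none of the four gives a number there.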